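The source may report more compounds than this note shows. Statements on the series, on what has been measured and on what is new or still open speak of the compounds shown alone.

Compound 1, `CCCCCCc1nc(C(F)(F)F)ccc1CNC(=O)C(C)c1ccc(NS(C)(=O)=O)c(F)c1`, is the starting point. In an assay on CHO cells for antagonist activity at transient receptor potential cation channel subfamily V member 1 (Homo sapiens), read by FLIPR and calcium flux (a lower number here means a stronger inhibitor, a higher number a weaker inhibitor), compound 1 gives 1.6 nM, the highest of the three numbers measured here. Compound 2, `CC(C(=O)NCc1ccc(C(F)(F)F)nc1CCC(C)(C)C)c1ccc(NS(C)(=O)=O)c(F)c1`, gives 0.6 nM in this assay, and compound 3, `CC(C(=O)NCc1ccc(C(F)(F)F)nc1C1=C[C@H](C)CCC1)c1ccc(NS(C)(=O)=O)c(F)c1`, gives 0.1 nM. The change that leads to compound 4, `CC(C(=O)NCc1ccc(C(F)(F)F)nc1C1=CCC(C)(C)CC1)c1ccc(NS(C)(=O)=O)c(F)c1`, is 4,4-dimethylcyclohex-1-en-1-yl in place of hexyl on an aromatic carbon. Among the compounds with values here, two measured steps bear on it. The closest is a 16-fold lower number from compound 1 to compound 3 (1.20 log units; beyond the scatter), where a six-membered ring with one double bond, carrying a single methyl group, also replaced the hexyl chain on the same aromatic carbon. The step of a 2.7-fold lower number from compound 1 to compound 2 (0.43 log units; beyond the scatter) shows that a branched chain in place of the straight one also lowered the number, though by less. Because the step of a 16-fold lower number from compound 1 to compound 3 (1.20 log units; beyond the scatter) was large, and compound 4 carries a ring of the same kind as compound 3 differing only in its methyl groups, a large step in the same direction is expected, estimated as an 8.0-fold lower number from compound 1 to compound 4 (0.90 log units; beyond the scatter). For compound 4 the expected value in this assay is 0.2 nM, within a range from 0.05 nM to 0.8 nM.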

Compound 4, inhibition constant: 0.2 nM
Beside the measured number, compound 4's estimate shows no gap at the digits printed; the measured number falls inside the stated range.
By their numbers in this assay, from the lowest: compounds 3 and 4 (each within the scatter of the next); then compound 2; then compound 1.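

In this assay, 4,4-dimethylcyclohex-1-en-1-yl and 3-methylcyclohex-1-en-1-yl cannot be told apart at this position, on an aromatic carbon next to the ring nitrogen: the step is a 2.0-fold higher number from compound 3 to compound 4 (0.30 log units; within the scatter). The gain over the straight chain therefore does not depend on one single placement of methyl groups on the ring, as a second ring gives an 8.0-fold lower number from compound 1 to compound 4 (0.90 log units; beyond the scatter). The ring also improves on the branched chain, with a 3.0-fold lower number from compound 2 to compound 4 (0.48 log units; beyond the scatter), so both ring compounds now have lower numbers than compound 2.

Still open, from the compounds shown here alone, is whether the double bond matters, which a saturated cyclohexyl group or a phenyl ring at this position would test. No measurement here explains why the ring compounds differ from the chain compounds.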